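This account rests on a few compounds, and the source may have more. Where it says the series, first, only, none or still open, it means among the compounds named here.

In a functional assay on HeLa cells (Homo sapiens) for antiproliferative activity, read by MTT assay, with a stated time of 48 h (a higher number here means a weaker inhibitor, a lower number a stronger inhibitor), compound 2 `C=C(c1ccc2c(c1)C=CC(C)(C)O2)c1ccc(OC)cc1NC(=O)CO` sits at the low end of the measured numbers with 100 nM. Compound 3 `COc1ccc(C(=O)c2cc(OC)c(OC)c(OC)c2)c(NC(=O)CN)c1` gives 130 nM, within the scatter of compound 2. Compound 1 `CCNCC(=O)Nc1cc(OC)ccc1C(=O)c1ccc(OC)c2c1C=CC(C)(C)O2` gives 4270 nM, beyond the scatter of compound 2 and on the weak side.

The next step leads to compound 4 `C=C(c1ccc2c(c1)C=CC(C)(C)O2)c1ccc(OC)cc1NC(=O)CNC`, with the change methylamino in place of hydroxy on a saturated chain carbon bound to a carbonyl carbon. Within the data shown here, no measured pair isolates this change. Two compounds carry a nitrogen on that side chain, and they point in different directions: compound 3 at 130 nM and compound 1 at 4270 nM. Both also differ from compound 2 elsewhere, so neither is a clean guide.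

In this assay, a modest rise in the number is expected, possibly none beyond the scatter. The expected change is a 2.0-fold higher number from compound 2 to compound 4 (0.30 log units; within the scatter). The estimate for compound 4 is 200 nM, with an expected range of 50 nM to 800 nM.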

Compound 4, half-maximal inhibitory concentration: 410 nM
Estimate against measurement, compound 4: 2.1-fold (0.31 log units) below; low and high end bracket the measured number.
By their numbers in this assay, from the lowest: compounds 2 and 3 (each within the scatter of the next); then compound 4; then compound 1.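

In this assay, among these compounds, the pair gives the first clean reading at this position: methylamino in place of hydroxy on a saturated chain carbon bound to a carbonyl carbon gives a 4.1-fold higher number from compound 2 to compound 4 (0.61 log units; beyond the scatter), with the rest of the structure unchanged. Hydroxy and methylamino each count 1 hydrogen-bond donor and 1 hydrogen-bond acceptor, so this step arises with those counts unchanged, while the entering group has 2 heavy atoms against 1. No measured evidence on hand accounts for the step.

The compounds shown leave open whether the step follows the nitrogen or its methyl, which an unsubstituted amine on the same carbon of the core of compound 2 would separate. From the compounds shown here alone, compound 3 carries such an amine but differs elsewhere, and a dimethylamino group or a longer chain at this place also remains untested in these data.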